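The source may hold more compounds than are shown below. What is called first, only, known or untested is meant among the compounds shown, and "the series" means these compounds.

Measured in a functional assay on T47D cells (Homo sapiens) for cytotoxicity, read by CCK-8 assay and cell counting, with stated times of 4 h and 2 days; a higher number here means a weaker inhibitor, a lower number a stronger inhibitor:
- compound 1 `Oc1cccc(-c2cc(-c3ccccc3Cl)cc(-c3ccccc3)n2)c1` gives 680 nM
- compound 2 `Oc1cccc(-c2cc(-c3cccc(Cl)c3)cc(-c3cccs3)n2)c1` gives 680 nM

Compound 2, at 680 nM, stands level with compound 1 in this assay. Compound 3 `Oc1cccc(-c2cc(-c3cccc(Cl)c3)cc(-c3ccccc3)n2)c1` carries phenyl in place of thiophen-2-yl on an aromatic carbon. No measured pair isolates this change, so its size is not shown directly. Compound 1, which also carries phenyl, gives 680 nM, so no step beyond the scatter is expected in either direction in this assay. The estimated 1.1-fold lower number from compound 2 to compound 3 (0.05 log units; within the scatter) therefore stays small. Compound 3 is expected at 600 nM, with an estimated range of 250 nM to 1500 nM.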

Compound 3, half-maximal inhibitory concentration: 680 nM
Compound 3: the middle estimate sits 1.1-fold (0.05 log units) below what was measured; low and high end bracket the measured number.
By their numbers in this assay, from the lowest: compounds 1, 2 and 3 (each within the scatter of the next).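

In this assay, phenyl in place of thiophen-2-yl on the aromatic carbon next to the ring nitrogen gives no change at the digits printed from compound 2 to compound 3 (within the scatter), so exchanging these two aromatic rings at this position leaves the read-out unmoved. Replacing 2-chlorophenyl with 3-chlorophenyl gives no change at the digits printed from compound 1 to compound 3 (within the scatter), the first direct view of that change, and it is equally flat. No supporting measurement bears on why these changes leave the value as it is. From the compounds shown here alone, whether an amine or a carboxylic acid in place of phenyl on that carbon would shift the value stays open. The same holds for a methoxy group in place of the chlorine.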